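The compounds below may be only part of what the source reports. "The series", "measured", "known", "first", "only" and "open" are said of these compounds alone.

Measured so far in a functional assay on Bel-7402 cells (Homo sapiens) for antiproliferative activity, read by MTT assay, with a stated time of 48 h (on this read-out higher numbers stand for weaker inhibition of growth and lower numbers for stronger inhibition of growth), with these results:
- Compound 1 (`COc1ccc(/C=C2\Cc3c(cc(OC)c(OC)c3OC)C2=O)cc1[N+](=O)[O-]`) gives 950 nM
- Compound 2 (`COc1cc(/C=C2\Cc3c(cc(OC)c(OC)c3OC)C2=O)cc(OC)c1OC`) gives 1580 nM
- Compound 3 (`COc1cc2c(c(OC)c1OC)C/C(=C\c1cc(OC)c(OC)c(OC)c1OC)C2=O`) gives > 10000 nM as a limit of the assay and not a number

Among the compounds with values here, compound 1 at 950 nM lies within the usual scatter of compound 2 and these two are the only real numbers so far. The next compound is compound 4 (`COc1ccc(/C=C2\Cc3c(cc(OC)c(OC)c3OC)C2=O)cc1F`) which carries fluoro in place of nitro on an aromatic carbon. Within the data shown here, no measured step makes this swap. Among the measured compounds shown here, the one measured step is an at least 6.3-fold higher number from compound 2 to compound 3 (0.80 log units; beyond the scatter) and it is a different change, methoxy in place of hydrogen on an aromatic carbon. It shows that one substitution can move this read-out beyond the scatter, so the range must stay wide. Still, compound 1 and compound 2 carry different groups and stay within the scatter of each other, so no clear direction is expected. The estimated step is a 1.3-fold higher number from compound 1 to compound 4 (0.10 log units; within the scatter) and it is expected to stay within the scatter. The estimate for compound 4 in this assay is 1200 nM with a range from 350 nM to 4500 nM expected.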

Compound 4, concentration for 50% growth inhibition: 491 nM
The estimate for compound 4 lay 2.4-fold (0.39 log units) above the measured number, within the range that was stated.
By their numbers in this assay, from the lowest: compounds 4, 1 and 2 (each within the scatter of the next, the first and the last beyond it). At a limit, above all of these: compound 3.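

Within the data shown here, replacing nitro with fluoro on this aromatic carbon, ortho to a methoxy group and meta to a large group, gives the first direct reading of a change at this position in this assay: a 1.9-fold lower number from compound 1 to compound 4 (0.29 log units; within the scatter). The swap removes 3 heavy atoms with 2 hydrogen-bond acceptors and brings in 1 heavy atom with none, yet the read-out stays within the scatter, so in this pair the nitro group is not required for this level of growth inhibition. No measurement shown here bears on why these two groups read alike.

Still open, as far as these compounds go, is how an amine, a carboxylic acid or a longer chain such as an ethoxy group would read at this same position. Also open, from the compounds shown here alone, is whether fluoro would read the same on other carbons of this ring.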